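A few compounds are considered here, and "the series" means these few. Any claim that something is new, unique, unknown or untested is made for them only; others in the source may bear on it.

Compound 1 `O=C1/C(=C/c2ccccc2F)CN(Cc2cn(Cc3cccc(Cl)c3)nn2)C/C1=C\c1ccccc1F`: 4300 nM
Compound 2 `Cc1ccc(/C=C2\CN(C(=S)SCc3cn(Cc4cccc(Cl)c4)nn3)C/C(=C\c3ccc(C)cc3)C2=O)cc1`: > 80000 nM (a limit of the assay, not a number)
Compound 3 `Cc1ccc(/C=C2\CN(Cc3cn(Cc4ccccc4F)nn3)C/C(=C\c3ccc(C)cc3)C2=O)cc1`: 9500 nM

In a functional assay on DU-145 cells (Homo sapiens) for cytotoxicity, read by MTT assay, with a stated time of 24 h (a lower number here means a stronger inhibitor, a higher number a weaker inhibitor), compound 1 gives 4300 nM, the lowest of the two true numbers, and its gap to compound 3 lies beyond the scatter. Compound 4 `O=C1/C(=C/c2ccccc2F)CN(Cc2cn(Cc3ccc(F)cc3)nn2)C/C1=C\c1ccccc1F` differs from compound 1 in one place: 4-fluorophenyl in place of 3-chlorophenyl on a saturated chain carbon bound to an aromatic nitrogen. In words, 4-fluorophenyl stands in place of 3-chlorophenyl on a saturated chain carbon bound to an aromatic nitrogen. Going by the values given here, no measured pair isolates this change. Compound 3 also carries a fluorine-bearing benzyl group and gives 9500 nM, so a slight lean towards a higher number seems reasonable. In this assay no step beyond the scatter is expected, and the estimated step is a 1.3-fold higher number from compound 1 to compound 4 (0.11 log units; within the scatter). For compound 4 the expected value is 5500 nM, with an estimated range of 2500 nM to 12000 nM.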

Compound 4, half-maximal inhibitory concentration: 8700 nM
Beside the measured number, compound 4's estimate is 1.6-fold (0.20 log units) below it; the range from low to high includes it.
By their numbers in this assay, from the lowest: compound 1; then compounds 4 and 3 (each within the scatter of the next). At a limit, above all of these: compound 2.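

Going by these compounds alone, for the first time a single change can be read on its own: in this assay, 4-fluorophenyl in place of 3-chlorophenyl gives a 2.0-fold higher number from compound 1 to compound 4 (0.31 log units; beyond the scatter). This modest step shows that the group on this saturated chain carbon bound to an aromatic nitrogen does affect the number. Nothing measured here explains the step. As far as these compounds go, the halogen and its place on the ring change together, so their separate contributions remain unknown. A 4-chlorophenyl group, which keeps the chlorine and moves it, would help pull them apart.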